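Fluoro for hydroxy: compound 3 to compound 4

The source may report more compounds than this note shows. Statements on the series, on what has been measured and on what is new or still open speak of the compounds shown alone.

The series shares a core carrying a carbamoyl group and a sugar side chain; the question is how the substituent on the aromatic carbon ortho to the carbamoyl group moves the cytotoxicity read-out. Compound 3 `NC(=O)c1nccc([C@@H]2O[C@H](CO)[C@@H](O)[C@H]2O)c1O` carries a hydroxy there. In an ADME assay on MDCK cells (Canis lupus familiaris) for cytotoxicity, read by CellTiter-Glo, with a stated time of 10 min (on this read-out higher numbers stand for lower toxicity in this test and lower numbers for higher toxicity in this test), compound 3 gives 2000 nM, the lowest of the two numbers available. Compound 2 `C#Cc1c([C@@H]2O[C@H](CO)[C@@H](O)[C@H]2O)ccnc1C(N)=O`, with ethynyl at the same carbon, gives 98000 nM in this assay. Compound 1 `CC(C)(C)C(=O)OCOP(=O)(OCOC(=O)C(C)(C)C)OC[C@H]1O[C@@H](c2ccnc(C(N)=O)c2F)[C@H](O)[C@@H]1O` is a phosphate ester of the fluoro analogue. In this assay compound 1 gives > 400000 nM, which is a limit of the assay and not a number. Among the compounds with values here, the single measured step, a 49-fold lower number from compound 2 to compound 3 (1.69 log units; beyond the scatter), shows hydroxy at this carbon far below ethynyl.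

Compound 4 `NC(=O)c1nccc([C@@H]2O[C@H](CO)[C@@H](O)[C@H]2O)c1F` differs from compound 3 in one place: fluoro in place of hydroxy on an aromatic carbon. Within the data shown here, the only step that bears on it is a 49-fold lower number from compound 2 to compound 3 (1.69 log units; beyond the scatter), read here with hydroxy leaving rather than entering, so a large rise in this assay is expected. Compound 1, which holds the same fluoro within a larger structure, sits at the limit of > 400000 nM in this assay, at which 1 of the 3 values shown sits, and is consistent with a high number for the fluoro analogue. Compound 4 is expected to give 60000 nM, between 10000 nM and 400000 nM, that is a 30-fold higher number from compound 3 to compound 4 (1.48 log units; beyond the scatter).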

Compound 4, half-maximal cytotoxic concentration: > 400000 nM
Compound 4: only a limit was reported; the forecaster's own chance of this, stated with the estimate: 20%; at least 6.6-fold (0.82 log units) between middle value and limit.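

In this assay, fluoro in place of hydroxy on this aromatic carbon gives an at least 200-fold higher number from compound 3 to compound 4 (2.30 log units; beyond the scatter), so the low number of compound 3 goes with the hydroxy and not with the shared core alone. Fluoro in place of ethynyl gives an at least 4.0-fold higher number from compound 2 to compound 4 (0.61 log units; beyond the scatter), which places all three groups in one order on this read-out, with hydroxy lowest, ethynyl higher and fluoro highest, each step beyond the scatter. Compound 4 gives > 400000 nM, which is a limit of the assay and not a number, so both steps fix only a minimum size, and the top of the read-out is now reached more than once in this short series: the limit of > 400000 nM in this assay, at which 2 of the 4 values shown sit.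

Going by these compounds, how far fluoro truly lies from ethynyl and hydroxy stays open, and so does any order between compound 4 and the phosphate ester compound 1, since neither has a number. The compounds shown also leave open whether the low number is particular to hydroxy at this carbon, or whether an amine or a methoxy group there would fall near compound 3 or near compound 4.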